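The compounds below may be only part of what the source reports. "The series", "measured", "known", "first", "only" and "open" are said of these compounds alone.

Measured compounds:
- compound 1, `CCON=C1CCC(CN2CCN(c3nc(=O)c4cc(C(F)(F)F)cc([N+](=O)[O-])c4s3)C[C@H]2C)CC1`: > 64 ug/mL
- compound 2, `CON=C1CCC(CN2CCN(c3nc(=O)c4cc(C(F)(F)F)cc([N+](=O)[O-])c4s3)CC2C)CC1`: > 64 ug/mL

The account concerns the pair of analogues sharing one core and differing only in the alkoxy group of the oxime. In an ADME assay on Vero cells (Chlorocebus sabaeus) for cytotoxicity (a higher number here means that more compound is tolerated, a lower number that less compound is tolerated), compound 2 reports > 64 ug/mL, which is a limit of the assay rather than a number. Compound 1 likewise reports > 64 ug/mL in this assay, again a limit. Both values therefore sit at the limit of > 64 ug/mL in this assay, at which 2 of the 2 values shown sit, so nothing ranks compound 2 against compound 1 on the numbers available.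

The unmeasured analogue is compound 3, `CCON=C1CCC(CN2CCN(c3nc(=O)c4cc(C(F)(F)F)cc([N+](=O)[O-])c4s3)CC2C)CC1`. It differs from compound 2 by methyl in place of hydrogen on a saturated chain carbon bound to an oxygen on an unsaturated carbon. For the measured compounds named here, no step between measured compounds is available to calibrate this change directly; the only guide is that compound 1, which carries the ethoxy oxime, also sits at the limit, as given by the limit of > 64 ug/mL in this assay, at which 2 of the 2 values shown sit.

The expectation is therefore that the step that the limit leaves unreadable from compound 2 to compound 3 is none beyond the scatter and that compound 3 is most likely reported as another limit. Compound 3 is estimated at 90 ug/mL, within a range from 45 ug/mL to 200 ug/mL.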

Compound 3, half-maximal cytotoxic concentration: > 64 ug/mL
Compound 3 gave a limit, no number; the forecaster's own chance of this, stated with the estimate: 85%; the middle value does not contradict the limit.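

In this assay compound 3 gives > 64 ug/mL, a limit and not a number. For the compounds shown here, no step among compound 1, compound 2 and compound 3 can be read: the limit of > 64 ug/mL in this assay, at which 3 of the 3 values shown sit. The compounds shown leave open whether methyl in place of hydrogen, or a defined configuration at the stereocentre, makes any difference in this assay.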